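The source may hold more compounds than are shown below. What is called first, only, known or untested is meant among the compounds shown, and "the series" means these compounds.

Measured in a functional assay on HT-29 cells (Homo sapiens) for cytotoxicity, read by MTT assay, with a stated time of 72 h; a higher number here means a weaker inhibitor, a lower number a stronger inhibitor:
- compound 1 `O=C(CN1CCN(c2nnc(Cc3ccccc3)c3ccccc23)CC1)Nc1ccc(F)c(C(F)(F)F)c1`: 4590 nM
- compound 2 `O=C(CN1CCN(c2nnc(Cc3ccncc3)c3ccccc23)CC1)Nc1ccc(F)c(C(F)(F)F)c1`: 1110 nM
- compound 3 `O=C(CN1CCN(c2nnc(Cc3ccccc3)c3ccccc23)CC1)Nc1cc(C(F)(F)F)ccc1Cl`: 66800 nM

Compound 2, at 1110 nM, has the lowest of the three numbers. Next is compound 4 `O=C(CN1CCN(c2nnc(Cc3ccncc3)c3ccccc23)CC1)Nc1ccc(F)c(F)c1`, with fluoro in place of trifluoromethyl on an aromatic carbon, ortho to a fluoro group. Going by the values given here, no measured step removes trifluoromethyl. Among the compounds with values here, the nearest precedent is the large change on the same aryl group, a 15-fold higher number from compound 1 to compound 3 (1.16 log units; beyond the scatter). The step of a 4.1-fold lower number from compound 1 to compound 2 (0.62 log units; beyond the scatter) is modest but lies elsewhere in the molecule. Within the data shown here, the single aryl precedent went upward, so direction is only weakly indicated. Expected in this assay is a modest rise, estimated as a 2.3-fold higher number from compound 2 to compound 4 (0.35 log units; beyond the scatter). For compound 4 the estimate is 2500 nM, with an expected range of 600 nM to 10000 nM.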

Compound 4, half-maximal inhibitory concentration: 2320 nM
The estimate for compound 4 lay 1.1-fold (0.03 log units) above the measured number; the range from low to high includes it.
By their numbers in this assay, from the lowest: compound 2; then compounds 4 and 1 (each within the scatter of the next); then compound 3.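

In this assay the trifluoromethyl group itself is exchanged here, and fluoro in its place gives a 2.1-fold higher number from compound 2 to compound 4 (0.32 log units; beyond the scatter) within the pyridin-4-yl series. This modest step is smaller than a 15-fold higher number from compound 1 to compound 3 (1.16 log units; beyond the scatter) for the earlier aryl change, so the loss of trifluoromethyl at this position alone gives only a limited shift. Nothing measured here explains the step.

Going by these compounds, whether the step holds with phenyl in place of pyridin-4-yl remains open. So does the outcome with a nitrile or a methoxy group on this aromatic carbon.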